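The source may hold more compounds than are shown below. What is called first, only, known or untested is meant among the compounds shown, and "the series" means these compounds.

Compound 1 `CS(=O)(=O)Nc1ccc2c(c1)S(=O)(=O)N=C(C1=C(O)C3CCCC3N(Cc3ccc(F)cn3)C1=O)N2` stands in an ADME assay on Huh-7 cells (Homo sapiens) for cytotoxicity, with a stated time of 72 h (on this read-out lower numbers stand for higher toxicity in this test and higher numbers for lower toxicity in this test), at > 33000 nM, which is a limit of the test and not a number. Compound 3 `CS(=O)(=O)Nc1ccc2c(c1)S(=O)(=O)N=C(C1=C(O)[C@H]3CCC[C@H]3N(Cc3cccc(C(F)(F)F)c3)C1=O)N2` likewise reaches only a limit in this assay, > 33000 nM. Compound 2 `CS(=O)(=O)Nc1ccc2c(c1)S(=O)(=O)N=C(C1=C(O)[C@H]3CCC[C@H]3N(Cc3ccc(F)c(Cl)c3)C1=O)N2` stops at another limit in this assay, > 1000 nM. Among the compounds with values here, the single change within the measured set, a step that the two limits leave unreadable from compound 2 to compound 3, cannot be read because the limit of > 1000 nM in this assay, at which 1 of the 3 values shown sits, and the limit of > 33000 nM in this assay, at which 2 of the 3 values shown sit, both cap the values. Compound 4 `CS(=O)(=O)Nc1ccc2c(c1)S(=O)(=O)N=C(C1=C(O)C3CCCC3N(CC3CCC3)C1=O)N2` carries cyclobutyl in place of 5-fluoropyridin-2-yl on a saturated chain carbon bound to an amide-type nitrogen in a ring. No readable measured step bears on this change; what the set shows is that compound 1 rests at the limit of > 33000 nM in this assay, at which 2 of the 3 values shown sit. Compound 4 is therefore expected to show again no toxicity up to that limit, at an estimated 50000 nM within 20000 nM to 150000 nM. The expected step is a step that the limit leaves unreadable from compound 1 to compound 4, none beyond the scatter.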

Compound 4, half-maximal cytotoxic concentration: > 33000 nM
Compound 4 gave a limit, no number; the forecaster's own chance of this, stated with the estimate: 85%; the middle value does not contradict the limit.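

No new step can be read: in this assay, compound 1 and compound 4 both give a limit and not a number. Going by these compounds, the concentration at which either compound becomes toxic in this assay remains open.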